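A few compounds are considered here, and "the series" means these few. Any claim that something is new, unique, unknown or untested is made for them only; others in the source may bear on it.

Measured compounds in a physicochemical assay for solubility, in phosphate buffer, at pH 7.4; a lower number here means a less soluble compound, a higher number a more soluble compound:
compound 1 `CNC(=O)Nc1cc(Oc2cncc(C)c2)c([C@H]2C[C@@H](O)C2)cn1` — 332000 nM
compound 2 `CNC(=O)Nc1cc(Oc2cncc(OC)c2)c([C@H]2CCCOC2)cn1` — 303000 nM

In this assay compound 1 gives 332000 nM, the highest of the two numbers, but compound 2 gives 303000 nM, which lies within the scatter of it, so no order between the two can be read from these figures. Compound 3 `CCOCCc1cnc(NC(=O)NC)cc1Oc1cncc(C)c1` has not yet been measured. It differs from compound 1 in one place: 2-ethoxyethyl in place of 3-hydroxycyclobutyl on an aromatic carbon. Within the data shown here, no measured pair differs in the same way, so there is no measured step of this kind to lean on. The group that enters carries no hydrogen-bond donor where the group that leaves carried one, and on that ground alone a moderate downward step, a 2.2-fold lower number from compound 1 to compound 3 (0.35 log units; beyond the scatter), is expected, somewhat beyond the scatter but not large. Compound 3 is estimated at 150000 nM, with a range from 50000 nM to 400000 nM.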

Compound 3, solubility: 500000 nM
Beside the measured number, compound 3's estimate is 3.3-fold (0.52 log units) below it, and the stated range ends below it.
By their numbers in this assay, from the lowest: compounds 2, 1 and 3 (each within the scatter of the next).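

In this assay, 2-ethoxyethyl in place of 3-hydroxycyclobutyl on this aromatic carbon gives a 1.5-fold higher number from compound 1 to compound 3 (0.18 log units; within the scatter), so this change cannot be told apart from the scatter. Among these compounds, at this position, then, a group with no ring, no defined stereocentres and 0 hydrogen-bond donors reads level with a four-membered ring group carrying 1 hydrogen-bond donor, at the same count of 5 heavy atoms, and the earlier compounds offered no such pair. No measurement at hand speaks to the reason for this.

The compounds shown leave open whether an amine, a carboxylic acid or a longer chain at this position would stand apart from these values in this assay. They also leave open whether the same change would read alike with something other than the (5-methylpyridin-3-yl)oxy group on the shared core.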